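A few compounds are considered here, and "the series" means these few. Any claim that something is new, unique, unknown or untested is made for them only; others in the source may bear on it.

Two compounds of this series have a measured value in a functional assay on CHO cells for antagonist activity at C-C chemokine receptor type 4 (Homo sapiens), read by GTPgammaS binding; a higher number here means a weaker inhibitor, a lower number a stronger inhibitor. Compound 1 `COc1cccc2c1c(NS(=O)(=O)c1ccc(Cl)s1)nn2Cc1cccc(CNC(=O)C(C)(C)N)c1` gives 15.9 nM. Compound 2 `COc1cc(F)cc2c1c(NS(=O)(=O)c1ccc(Cl)s1)nn2Cc1cccc(CNC(C)=O)c1` gives 39.8 nM, the higher of the two numbers, so of these two compound 2 is the weaker inhibitor. Compound 3 `COc1cc(F)cc2c1c(NS(=O)(=O)c1ccc(Cl)s1)nn2Cc1cccc(CNC(=O)C(C)(C)O)c1` has not yet been measured; it differs from compound 2 in one place: 1-hydroxy-1-methylethyl in place of methyl on a carbonyl carbon. For the measured compounds named here, no step between two measured compounds shows this exact change. Compound 1 carries a related side chain, with an amino group where compound 3 carries a hydroxyl, and compound 1 also differs from compound 2 elsewhere, so its lower number only loosely suggests that such a larger group need not raise the number. For compound 3 the expected step of a 1.4-fold lower number from compound 2 to compound 3 (0.15 log units; within the scatter) is small, within the scatter or slightly downward. Compound 3 is therefore estimated at 28 nM, with a range from 10 nM to 80 nM.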

Compound 3, half-maximal inhibitory concentration in the C-C chemokine receptor type 4 assay: 15.9 nM
Compound 3: the middle estimate sits 1.8-fold (0.25 log units) above what was measured; the measured number falls inside the stated range.
By their numbers in the C-C chemokine receptor type 4 assay, from the lowest: compounds 1 and 3 (each within the scatter of the next); then compound 2.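

For the compounds shown here, replacing methyl with 1-hydroxy-1-methylethyl on this carbonyl carbon gives in the C-C chemokine receptor type 4 assay a modest step (a 2.5-fold lower number from compound 2 to compound 3 (0.40 log units; beyond the scatter)) and the first direct reading of any change at this place: compound 2 gives 39.8 nM and compound 3 gives 15.9 nM so the larger group is accepted here, and the number goes down. In a physicochemical assay for lipophilicity (a lower number here means a more polar compound, a higher number a more lipophilic compound), the same change takes compound 2 at 4.1 to compound 3 at 4.2 (a number 0.10 log units higher from compound 2 to compound 3 (within the scatter)) so the lower inhibitory number comes with no shift beyond the scatter in the distribution coefficient. Nothing available explains why the inhibitory number falls.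

Going by these compounds, the whole group changes in a single step, so it remains open whether the hydroxyl or the added carbons account for it; a 1-methylethyl or a hydroxymethyl on the same carbonyl carbon would separate the two. Also open, on these data alone, is how a longer chain or a carboxylic acid would behave there.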